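A few compounds are considered here, and "the series" means these few. Any claim that something is new, unique, unknown or untested is made for them only; others in the source may bear on it.

Measured so far in a physicochemical assay for solubility, at pH 7; a lower number here means a less soluble compound, a higher number a more soluble compound:
- Compound 1 (`CN1CCC(C(=O)N2Cc3c(NC(=O)C4CC4)n[nH]c3C2(C)C)CC1`) gives > 225000 nM
- Compound 2 (`CC1(C)c2[nH]nc(NC(=O)c3ccc(F)cc3)c2CN1C(=O)C1CCN(C2CC2)CC1`) gives > 225000 nM

Both entries are limits of the assay and not numbers. Compound 1 stands at > 225000 nM as a limit, so its true solubility is not known. The same holds for compound 2, and the limit of > 225000 nM in this assay, at which 2 of the 2 values shown sit, is all that the measurements show so far.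

Compound 3 (`CN1CCC(C(=O)N2Cc3c(NC(=O)c4ccc(F)c(F)c4)n[nH]c3C2(C)C)CC1`) has not yet been measured. It keeps the core of compound 1 and changes one group, with 3,4-difluorophenyl in place of cyclopropyl on a carbonyl carbon. Among the compounds with values here, no measured pair isolates this kind of change. The closest guide is compound 2, which also has an aromatic ring on that kind of carbonyl and still gives > 225000 nM as a limit. The step of an at least 1.1-fold lower number from compound 1 to compound 3 (0.07 log units; that floor lies within the scatter) is therefore expected to be small and downward, if it goes beyond the scatter at all. this assay may well report only a limit again. For compound 3 the estimated solubility is 190000 nM with an expected range from 80000 nM to 225000 nM in this estimate.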

Compound 3, solubility: > 225000 nM
Compound 3 ended at the assay's limit; the forecaster's own chance of this, stated with the estimate: 60%; middle value at least 1.1-fold (0.07 log units) from the limit.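

Compound 3 gives > 225000 nM, which is a limit and not a number. Within the data shown here, compound 1 also sits at a limit, so no step from compound 1 to compound 3 can be read. The compounds shown leave open the true solubility of each, and whether 3,4-difluorophenyl in place of cyclopropyl on a carbonyl carbon changes it at all: the limit of > 225000 nM in this assay, at which 3 of the 3 values shown sit.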